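This account rests on a few compounds, and the source may have more. Where it says the series, first, only, none or still open, it means among the compounds named here.

Three analogues sharing one core have been measured in a functional assay on HCT-116 cells (Homo sapiens) for cytotoxicity; a higher number here means that more compound is needed for the effect, a lower number that less compound is needed. Compound 1 `CC(=O)SCC(=O)c1ccc(NS(=O)(=O)c2ccc(OC3CCCN(C)C3)cc2)nc1` gives 3700 nM. Compound 2 `CC(=O)SCC(=O)c1ccc(NS(=O)(=O)c2ccc(OCCCO)cc2)nc1` gives 8600 nM, and compound 3 `CC(=O)SCC(=O)c1ccc(NS(=O)(=O)c2ccc(OCc3ccccn3)cc2)nc1` gives 420 nM. Compound 3 therefore stands lowest of the three, with the nearest number from compound 1 and the furthest from compound 2; the step of an 8.8-fold lower number from compound 1 to compound 3 (0.94 log units; beyond the scatter) and the step of a 20-fold lower number from compound 2 to compound 3 (1.31 log units; beyond the scatter) both point toward compound 3.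

Compound 4 `CC(=O)SCC(=O)c1ccc(NS(=O)(=O)c2ccc(OCCCN3CCCC3)cc2)nc1` differs from compound 3 in one place: 2-(pyrrolidin-1-yl)ethyl in place of pyridin-2-yl on a saturated chain carbon bound to an oxygen on an aromatic ring. Going by the values given here, two measured steps bear on this change. Compound 1 carries a saturated amine ring on that oxygen, and the step from it to the pyridine, an 8.8-fold lower number from compound 1 to compound 3 (0.94 log units; beyond the scatter), was modest. Compound 2 carries a flexible chain in the same place, and a 20-fold lower number from compound 2 to compound 3 (1.31 log units; beyond the scatter) was large. Since compound 4 combines a saturated amine with a flexible chain, the account expects a higher number in this assay for it, estimated as a 7.1-fold higher number from compound 3 to compound 4 (0.85 log units; beyond the scatter). Compound 4 is thus expected at 3000 nM, with a range from 1000 nM to 9000 nM.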

Compound 4, half-maximal effective concentration: 820 nM
Estimate against measurement, compound 4: 3.7-fold (0.56 log units) above, and the stated range ends above it.
By their numbers in this assay, from the lowest: compounds 3 and 4 (each within the scatter of the next); then compound 1; then compound 2.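

In this assay, the step from the (pyridin-2-yl)methyl group to the 3-(pyrrolidin-1-yl)propyl group on this oxygen stays within the scatter (a 2.0-fold higher number from compound 3 to compound 4 (0.29 log units; within the scatter)), so an aromatic pyridine ring is not required to reach this range among the compounds shown. On the same chain, pyrrolidin-1-yl in place of hydroxy gives a large step (a 10-fold lower number from compound 2 to compound 4 (1.02 log units; beyond the scatter)), and 3-(pyrrolidin-1-yl)propyl in place of 1-methylpiperidin-3-yl gives a modest one (a 4.5-fold lower number from compound 1 to compound 4 (0.65 log units; beyond the scatter)), so the two saturated amines on this oxygen do not fall at one level. No measurement at hand explains these steps.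

On these data alone, whether the pyrrolidine keeps this level on a shorter or longer chain stays open. So does whether a morpholine, a primary amine or a carboxylic acid at the end of the propyl chain would read like compound 4 or like compound 2.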